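Extending the Ureido Group: From Compound 1 to Compound 4

The source may hold more compounds than are shown below. What is called first, only, known or untested is meant among the compounds shown, and "the series" means these compounds.

Compound 1 `Cc1cn([C@@H]2O[C@H](CO[Si](C)(C)C(C)(C)C)[C@@]3(OS(=O)(=O)C=C3NC(N)=O)[C@H]2O[Si](C)(C)C(C)(C)C)c(=O)n(C)c1=O` is the reference point of this small set. In a functional assay on HEL cells (Homo sapiens) (a lower number here means that less compound is tolerated, a higher number that more compound is tolerated), compound 1 gives 11000 nM, the lowest of the two numbers obtained, the nearer of them coming from compound 3 at a distance of an 18-fold higher number from compound 1 to compound 3 (1.26 log units; beyond the scatter). Compound 3 `Cc1cn([C@@H]2O[C@H](CO[Si](C)(C)C(C)(C)C)[C@@]3(OS(=O)(=O)C=C3NCCC(=O)OCc3ccccc3)[C@H]2O[Si](C)(C)C(C)(C)C)c(=O)n(C)c1=O` carries a 2-(benzyloxycarbonyl)ethyl in place of carbamoyl on an amine nitrogen, and in this assay compound 3 gives 200000 nM. Compound 2 `Cc1cn([C@@H]2O[C@H](CO[Si](C)(C)C(C)(C)C)[C@@]3(OS(=O)(=O)C=C3NC(=O)NC(=O)c3ccccc3)[C@H]2O[Si](C)(C)C(C)(C)C)c(=O)n(C)c1=O`, with benzoyl in place of hydrogen on an amide-type nitrogen, reaches only a limit of the assay: in this assay compound 2 gives >= 200000 nM. The corresponding step is an at least 18-fold higher number from compound 1 to compound 2 (1.25 log units; beyond the scatter). Both changes away from compound 1 thus pushed the number strongly upward.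

Compound 4 `Cc1cn([C@@H]2O[C@H](CO[Si](C)(C)C(C)(C)C)[C@@]3(OS(=O)(=O)C=C3NCCC(N)=O)[C@H]2O[Si](C)(C)C(C)(C)C)c(=O)n(C)c1=O` has not been measured. It differs from compound 1 by 2-carbamoylethyl in place of carbamoyl on an amine nitrogen. The closest measured precedent is the exchange of carbamoyl for a longer chain on the same amine nitrogen, which gave an 18-fold higher number from compound 1 to compound 3 (1.26 log units; beyond the scatter). Compound 4, whose new chain ends in an amide rather than a benzyl ester, is expected to move in the same direction but by a smaller amount, a 5.5-fold higher number from compound 1 to compound 4 (0.74 log units; beyond the scatter). Compound 4 is accordingly estimated at 60000 nM, with a range from 15000 nM to 200000 nM.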

Compound 4, half-maximal cytotoxic concentration: 14800 nM
The estimate for compound 4 lay 4.1-fold (0.61 log units) above the measured number, outside the stated range (below it).
By their numbers in this assay, from the lowest: compounds 1 and 4 (each within the scatter of the next); then compound 3.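

In this assay the 2-carbamoylethyl group on the amine nitrogen cannot be told apart from carbamoyl, with a 1.3-fold higher number from compound 1 to compound 4 (0.13 log units; within the scatter), so a longer chain on this nitrogen does not by itself go with a large step. What separates the two chains is the group on the carbonyl carbon: with amino in place of benzyloxy the result is a 14-fold lower number from compound 3 to compound 4 (1.13 log units; beyond the scatter), which places the large number of compound 3 with its benzyl ester rather than with the chain that compound 3 shares with compound 4. As far as these compounds go, compound 4 also lies far from compound 2, at an at least 13-fold lower number from compound 2 to compound 4 (1.13 log units; beyond the scatter), but that step starts from a limit of the assay held by compound 2, so its full size stays open: the limit of >= 200000 nM in this assay, at which 1 of the 4 values shown sits.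

The compounds shown leave open whether a benzylamino group on the same carbonyl carbon would go with the number of compound 3 or that of compound 4, which would show whether the benzene ring or the ester matters. They also leave open where a carboxylic acid or a methyl ester on this chain would stand, and whether a longer chain ending in carbamoyl would still match compound 1.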